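The compounds below may be only part of what the source reports. "The series", "measured", "known", "first", "only" and "open" are said of these compounds alone.

In a functional assay on MCF7 cells (Homo sapiens) for cytotoxicity, read by MTT assay, with a stated time of 72 h (a higher number here means a weaker inhibitor, a lower number a stronger inhibitor), compound 3 `O=C(CCl)Nc1ccc(C(=O)/C=C/c2ccccc2)cc1` gives 2480 nM, the lowest of the two numbers recorded in the series. Its nearest neighbour, compound 1 `O=C(CSC(=S)N[C@H]1CCOC1=O)Nc1ccccc1F`, gives 28600 nM in this assay, a higher number that lies beyond the scatter. Compound 2 `CCCCSC(=S)N[C@H]1CCOC1=O` returns only > 128000 nM, which is a limit of this assay and not a number; the same holds for (the limit of > 128000 nM in this assay, at which 1 of the 3 values shown sits).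

Compound 4 `O=C(CCl)Nc1ccc(C(=O)/C=C/c2ccccc2Cl)cc1` is compound 3 with chloro in place of hydrogen on an aromatic carbon, ortho to a large group. No measured step of this kind exists among these compounds, so the expected step from compound 3 to compound 4 in this assay, a 1.2-fold lower number from compound 3 to compound 4 (0.09 log units; within the scatter), is estimated as none beyond the scatter. Compound 4 is therefore expected to give about 2000 nM, estimated between 700 nM and 6000 nM.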

Compound 4, half-maximal inhibitory concentration: 5260 nM
The estimate for compound 4 lay 2.6-fold (0.42 log units) below the measured number; the range from low to high includes it.
By their numbers in this assay, from the lowest: compound 3; then compound 4; then compound 1. At a limit, above all of these: compound 2.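

In this assay, within the data shown here, this is the first measured single-place change: phenyl to 2-chlorophenyl gives a 2.1-fold higher number from compound 3 to compound 4 (0.33 log units; beyond the scatter). Chloro ortho to a large group is therefore tolerated at this position, but with a modest loss rather than a gain. Nothing measured here accounts for this step.

As far as these compounds go, whether the loss is specific to chloro remains open, since a methoxy group or an amine on the same aromatic carbon could shift the number differently. From the compounds shown here alone, whether a second substituent on that ring would add to the step also remains open.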